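The source may report more compounds than this note shows. Statements on the series, on what has been measured and on what is new or still open speak of the compounds shown alone.

Among the measured compounds shown here, in a functional assay on MGC-803 cells (Homo sapiens) for inhibition, read by MTT assay, with a stated time of 72 h (on this read-out higher numbers stand for weaker inhibition and lower numbers for stronger inhibition), compound 1 `Cc1cc(Nc2cc(-c3ccccc3)[nH]n2)n2ncnc2n1` gives 21700 nM, the highest of the three numbers so far. Compound 2 `Cc1cc(Nc2cc(-c3cccs3)[nH]n2)n2nc(SCc3ccc(Br)cc3)nc2n1` gives 3770 nM and compound 3 `Cc1cc(Nc2ccn(Cc3ccc(C(F)(F)F)cc3)n2)n2nc(SCc3ccc(Br)cc3)nc2n1` gives 2590 nM; both lie beyond the scatter below compound 1. For the measured compounds named here, no single-point step between measured compounds is available, as compounds 2 and 3 differ from compound 1 in more than one place. Compound 4 `Cc1cc(Nc2cc(-c3ccccc3)[nH]n2)n2nc(SCC(=O)c3ccccc3)nc2n1` is not yet measured; it differs from compound 1 by (benzoylmethyl)sulfanyl in place of hydrogen on an aromatic carbon, the group entering on the aromatic carbon between two ring nitrogen atoms. A downward step beyond the scatter is expected, a 4.3-fold lower number from compound 1 to compound 4 (0.64 log units; beyond the scatter), because compound 2 at 3770 nM and compound 3 at 2590 nM carry a substituent at that same place. Compound 4 is estimated at 5000 nM, range 1500 nM to 16000 nM.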

Compound 4, half-maximal inhibitory concentration: 2580 nM
The estimate for compound 4 lay 1.9-fold (0.29 log units) above the measured number; low and high end bracket the measured number.
By their numbers in this assay, from the lowest: compounds 4, 3 and 2 (each within the scatter of the next); then compound 1.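

In this assay, (benzoylmethyl)sulfanyl in place of hydrogen on the aromatic carbon between two ring nitrogen atoms gives an 8.4-fold lower number from compound 1 to compound 4 (0.92 log units; beyond the scatter). Among the compounds shown here, this is the first change at this position with the rest of compound 1 held constant, showing that this substitution alone goes with stronger inhibition, which compounds 2 and 3, differing from compound 1 in more than one place, could not show. No measurement at hand accounts for the step. Still open, as far as these compounds go, is which part of the group carries the step; a methylsulfanyl group or an amine on the same carbon would test this.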